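The compounds below may be only part of what the source reports. "The series", "measured", "known", "first", "only" and "open" are said of these compounds alone.

Values in a functional assay on MC-38 cells (Mus musculus) for antiproliferative activity, read by CCK-8 assay, with a stated time of 48 h; on this read-out higher numbers stand for weaker inhibition and lower numbers for stronger inhibition:
Compound 1 `COc1ccc(/C=C\c2cc(OC)c(OC)c(OC)c2)cc1OCc1ccc(CN2C[C@H](O)C[C@@H]2C(=O)O)cc1`: > 10000 nM (a limit of the assay)
Compound 2 `COc1ccc(/C=C\c2cc(OC)c(OC)c(OC)c2)cc1OCc1ccc(CO)cc1`: 5700 nM
Compound 3 `COc1ccc(/C=C\c2cc(OC)c(OC)c(OC)c2)cc1OCc1ccc(CN2CC[C@H](O)C2)cc1`: 7200 nM

Among the compounds with values here, compound 3 gives 7200 nM, which lies within the scatter of the only other actual number: a 1.3-fold higher number from compound 2 to compound 3 (0.10 log units; within the scatter). Compound 1 reports only a limit.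

Compound 4 `COc1ccc(/C=C\c2cc(OC)c(OC)c(OC)c2)cc1OCc1ccc(CNCCN(C)C)cc1` carries (2-(dimethylamino)ethyl)amino in place of 3-hydroxypyrrolidin-1-yl on a saturated chain carbon bound to an aromatic carbon. Three measured steps changed the group at this same place. Two start from a limit and give only floors: an at least 1.7-fold lower number from compound 1 to compound 2 (0.24 log units; that floor lies within the scatter) and an at least 1.3-fold lower number from compound 1 to compound 3 (0.14 log units; that floor lies within the scatter). Within the data shown here, the one step between two actual numbers is the most useful guide, and it stayed within the scatter: a 1.3-fold higher number from compound 2 to compound 3 (0.10 log units; within the scatter). On that basis, no step beyond the scatter is expected in this assay, and no direction can be favoured. The expected step is a 1.4-fold lower number from compound 3 to compound 4 (0.16 log units; within the scatter). For compound 4 the estimated value is 5000 nM, with an expected range of 1500 nM to 14000 nM.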

Compound 4, half-maximal inhibitory concentration: 1400 nM
Beside the measured number, compound 4's estimate is 3.6-fold (0.55 log units) above it; measured number below the stated range.
By their numbers in this assay, from the lowest: compound 4; then compounds 2 and 3 (each within the scatter of the next). At a limit, above all of these: compound 1.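

In this assay, the place on a saturated chain carbon bound to an aromatic carbon now shows steps beyond the scatter, with a 5.1-fold lower number from compound 3 to compound 4 (0.71 log units; beyond the scatter) and a 4.1-fold lower number from compound 2 to compound 4 (0.61 log units; beyond the scatter) among the compounds shown. The earlier changes here gave only a step or floors within the scatter, whereas (2-(dimethylamino)ethyl)amino, which has no ring but the same count of heavy atoms as 3-hydroxypyrrolidin-1-yl, gives the lowest number of the series. Compound 1 reports a limit, so an at least 7.1-fold lower number from compound 1 to compound 4 (0.85 log units; beyond the scatter) is a floor, though one printed beyond the scatter: the limit of > 10000 nM in this assay, at which 1 of the 4 values shown sits.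

The compounds shown do not separate the loss of the ring from the entry of the second nitrogen. Going by these compounds, how a piperazine ring, a primary amine or a longer chain would read at this place also stays open.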